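The compounds below may be only part of what the source reports. "The series", "measured", "known", "first", "only" and "open" are said of these compounds alone.

Among the measured compounds shown here, compound 1 `COc1ccc(CNC(=O)/C(C#N)=C/c2ccc[nH]2)cc1` is one of two compounds so far tested in a functional assay on A2780 cells (Homo sapiens) for inhibition, read by MTT assay, with a stated time of 72 h; a lower number here means a stronger inhibitor of growth, a higher number a weaker inhibitor of growth. In this assay compound 1 gives > 50000 nM, which is a limit of the assay and not a number. Compound 2 `N#C/C(=C\c1ccc[nH]1)C(=O)NCc1ccc(Cl)c(Cl)c1` was tested alongside it, and in this assay compound 2 gives > 50000 nM, again a limit. For the measured compounds named here, the only evidence available is the limit of > 50000 nM in this assay, at which 2 of the 2 values shown sit, so compound 1 has no measured standing apart from that limit. Compound 3 `COc1ccc(CNC(=O)/C(C#N)=C/c2ccco2)cc1` differs from compound 1 by furan-2-yl in place of 1H-pyrrol-2-yl on a double-bonded chain carbon bound to a double-bonded chain carbon. Without any measured step to guide the size, the expected step is a step that the limit leaves unreadable from compound 1 to compound 3, none beyond the scatter. Compound 3 is therefore estimated at 60000 nM, ranging from 20000 nM to 200000 nM, most probably reported once more only as a limit.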

Compound 3, concentration for 50% growth inhibition: 24000 nM
Estimate against measurement, compound 3: 2.5-fold (0.40 log units) above; the measured number falls inside the stated range.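

In this assay, furan-2-yl in place of 1H-pyrrol-2-yl gives an at least 2.0-fold lower number from compound 1 to compound 3 (0.31 log units; beyond the scatter), so activity at this place on the chain does depend on the ring it carries, which the two earlier compounds could not show. The change also swaps a hydrogen-bond donor for an acceptor, but one step cannot say whether that count matters. The true size of the step stays unknown, since its starting point is a limit: the limit of > 50000 nM in this assay, at which 2 of the 3 values shown sit.

On these data alone, whether a thiophene or phenyl ring at this place would lower the number further remains open. So does whether furan-2-yl would have a similar effect on the core of compound 2.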